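A few compounds are considered here, and "the series" means these few. Any claim that something is new, unique, unknown or untested is made for them only; others in the source may bear on it.

Of the compounds shown here, two that share one core have been measured so far. Compound 1 `C#CC(=O)N1C(c2ccc(C#N)cc2)SC[C@@H]1C(=O)OCC` and compound 2 `C#CC(=O)N1C(C(C)CCC)SC[C@@H]1C(=O)OCC` were tested in a functional assay on Huh-7 cells (Homo sapiens) for inhibition, read by sulforhodamine B assay; on this read-out higher numbers stand for weaker inhibition and lower numbers for stronger inhibition; there compound 1 gives 2600 nM, and compound 2 gives 600 nM. Compound 2 therefore holds the lower of the two numbers, and its gap to compound 1 is wider than repeated testing usually produces. Compound 3 `C#CC(=O)N1C(c2ccccc2)SC[C@@H]1C(=O)OCC` is still unmeasured. It differs from compound 2 in one place: phenyl in place of 1-methylbutyl on a saturated ring carbon. Going by the values given here, no measured pair shows this exchange, so the size of the step can only be estimated. With only the reading of compound 1 at 2600 nM as a second point, the step from compound 2 to compound 3 is expected to go toward weaker inhibition, with a size of a 3.0-fold higher number from compound 2 to compound 3 (0.48 log units; beyond the scatter) that is estimated to reach beyond the scatter. Compound 3 is thus expected to give about 1800 nM, within a range of 600 nM to 5000 nM.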

Compound 3, half-maximal inhibitory concentration: 5300 nM
Estimate against measurement, compound 3: 2.9-fold (0.47 log units) below; measured number outside the range, above it.
By their numbers in this assay, from the lowest: compound 2; then compound 1; then compound 3.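

In this assay the saturated ring carbon that carries 1-methylbutyl in compound 2 proves sensitive to its substituent: phenyl in place of 1-methylbutyl gives an 8.8-fold higher number from compound 2 to compound 3 (0.95 log units; beyond the scatter) and so clearly weaker inhibition. Substitution on the phenyl ring also counts, since hydrogen in place of cyano on an aromatic carbon gives a 2.0-fold higher number from compound 1 to compound 3 (0.31 log units; beyond the scatter) as a smaller step that still lies beyond the scatter. Nothing available explains either step.

As far as these compounds go, it remains open whether a cyclohexyl group at the same ring carbon would read closer to 1-methylbutyl or to phenyl, which would help separate the presence of a ring from its aromatic character. From the compounds shown here alone, it is equally open whether a methoxy group or a fluorine on the phenyl ring would match the cyano group.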